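Allyl in Place of Cyclohexyl on the Amino Nitrogen

A few compounds are considered here, and "the series" means these few. Any claim that something is new, unique, unknown or untested is made for them only; others in the source may bear on it.

Of the compounds shown here, three sharing one core have been measured in a functional assay on MOLT-4 cells (Homo sapiens) for cytotoxicity, read by MTT assay, with a stated time of 48 h; a higher number here means a weaker inhibitor, a lower number a stronger inhibitor. Compound 1 `Nc1ccccc1Nc1n[n+]([O-])c2ccccc2[n+]1[O-]` gives 2300 nM, compound 2 `COc1ccc(Nc2n[n+]([O-])c3ccccc3[n+]2[O-])cc1` gives 600 nM, and compound 3 `[O-][n+]1nc(NC2CCCCC2)[n+]([O-])c2ccccc21` gives 1300 nM in this assay. On these numbers compound 3 stands second highest of the three: the gap between compound 3 and compound 1 lies within the usual scatter of repeated measurements, so no order between them can be claimed, whereas compound 2 gives a lower number than compound 3 by a gap that lies beyond the scatter. Among the measured compounds shown here, no step between two measured compounds that differ in a single place is available here.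

The compound awaiting measurement is compound 4 `C=CCNc1n[n+]([O-])c2ccccc2[n+]1[O-]`. It differs from compound 3 in one place: allyl in place of cyclohexyl on a nitrogen on an aromatic ring. The cyclohexyl group, a six-membered non-aromatic ring of carbon only, gives way to a three-carbon chain carrying one double bond outside aromatic rings.

Because compound 3 gives 1300 nM and the measured set holds no comparable exchange of a ring for a short chain, the direction of the step is uncertain, and a modest move toward a higher number or none beyond the scatter is expected. Compound 4 is therefore estimated at 2000 nM, with a range from 800 nM to 5000 nM, which corresponds to an expected step of a 1.5-fold higher number from compound 3 to compound 4 (0.19 log units; within the scatter).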

Compound 4, half-maximal inhibitory concentration: 3000 nM
Beside the measured number, compound 4's estimate is 1.5-fold (0.18 log units) below it, and the stated range covers the measured number.
By their numbers in this assay, from the lowest: compound 2; then compounds 3, 1 and 4 (each within the scatter of the next, the first and the last beyond it).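

In this assay, among the compounds shown here, the exchange on a nitrogen on an aromatic ring gives a 2.3-fold higher number from compound 3 to compound 4 (0.36 log units; beyond the scatter), and this is the first single change in the set that can be read at all. The step is modest, but it lies beyond the scatter, so the group on this nitrogen is not indifferent to the read-out: of the two groups compared, cyclohexyl, a six-membered non-aromatic ring of carbon only, goes with the lower number and allyl with the higher. Nothing measured here bears on why the number moves with this exchange.

The exchange removes the ring, shortens the group and brings in a double bond all at once, so the compounds shown cannot say which of these goes with the step; propyl, a three-carbon chain without the double bond, and hexyl, an open chain of six carbons, would pull these apart. Also open, as far as these compounds go, is how phenyl on this nitrogen would stand against cyclohexyl and allyl on the shared core, which would link this pair to the compounds carrying a substituted benzene ring there.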